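Amide side chains on a shared core: towards compound 4

A few compounds are considered here, and "the series" means these few. Any claim that something is new, unique, unknown or untested is made for them only; others in the source may bear on it.

In a functional assay on BXPC-3 cells (Homo sapiens) for antiproliferative activity, read by MTT assay, with a stated time of 24 h (on this read-out lower numbers stand for stronger inhibition and higher numbers for weaker inhibition), compound 1 `CCn1c(C(=O)NCC(=O)OC)ccc1C(CC)(CC)c1ccc(OCS(=O)(=O)c2ccccc2)c(C)c1` gives 20000 nM and compound 2 `CCn1c(C(=O)N[C@@H](CO)C(C)C)ccc1C(CC)(CC)c1ccc(OCS(=O)(=O)c2ccccc2)c(C)c1` gives 13200 nM as measured values. The step between them is a 1.5-fold lower number from compound 1 to compound 2 (0.18 log units; within the scatter) in this pair.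

Compound 3 `CCn1c(C(=O)N[C@@H](CO)CCO)ccc1C(CC)(CC)c1ccc(OCS(=O)(=O)c2ccccc2)c(C)c1` stands at > 50000 nM in this assay and this is a limit, not a number (the limit of > 50000 nM in this assay, at which 1 of the 3 values shown sits).

Compound 4 `CCn1c(C(=O)N[C@@H](C)C(=O)O)ccc1C(CC)(CC)c1ccc(OCS(=O)(=O)c2ccccc2)c(C)c1` carries the change 1-carboxyethyl in place of 3-hydroxy-1-(hydroxymethyl)propyl on an amide-type nitrogen with 1-carboxyethyl in place of 3-hydroxy-1-(hydroxymethyl)propyl on an amide-type nitrogen. For the measured compounds named here, two steps bear on it: an at least 2.5-fold higher number from compound 1 to compound 3 (0.39 log units; beyond the scatter) and an at least 3.7-fold higher number from compound 2 to compound 3 (0.57 log units; beyond the scatter) on the same nitrogen. Going by the values given here, no measured compound holds 1-carboxyethyl, so these steps give only a loose guide.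

The estimated step is an at least 1.4-fold lower number from compound 3 to compound 4 (0.15 log units; that floor lies within the scatter) and no shift beyond the scatter is expected. For compound 4 the estimate is 35000 nM with an expected range from 12000 nM to 60000 nM in this series.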

Compound 4, half-maximal inhibitory concentration: 20800 nM
The estimate for compound 4 lay 1.7-fold (0.23 log units) above the measured number; low and high end bracket the measured number.
By their numbers in this assay, from the lowest: compounds 2, 1 and 4 (each within the scatter of the next). At a limit, above all of these: compound 3.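

In this assay the 1-carboxyethyl side chain on the amide-type nitrogen falls in with (methoxycarbonyl)methyl and 1-(hydroxymethyl)-2-methylpropyl: the steps of a 1.0-fold higher number from compound 1 to compound 4 (0.02 log units; within the scatter) and a 1.6-fold higher number from compound 2 to compound 4 (0.20 log units; within the scatter) both stay small. Only 3-hydroxy-1-(hydroxymethyl)propyl stands apart so far, with an at least 2.4-fold lower number from compound 3 to compound 4 (0.38 log units; beyond the scatter) as its step to 1-carboxyethyl. That step starts from a limit and not from a number: the limit of > 50000 nM in this assay, at which 1 of the 4 values shown sits.

From the compounds shown here alone, the true size of that gap stays open. So does whether an amine or a longer chain on this nitrogen would move the number beyond the scatter.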